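Oxazolidinone series: anilino to cyclopropylamino swap in lipophilicity

The source may hold more compounds than are shown below. What is called first, only, known or untested is meant among the compounds shown, and "the series" means these compounds.

Measured so far:
compound 1 `CC(=O)NC[C@H]1CN(c2ccc(OC[C@H](O)CNc3ccccc3)c(F)c2)C(=O)O1` — 0.59
compound 2 `CC(=O)NC[C@H]1CN(c2ccc(OC[C@@H](O)CNc3ccc(C#N)cc3)c(F)c2)C(=O)O1` — 2.12
compound 3 `CC(=O)NC[C@H]1CN(c2ccc(OC[C@@H](O)CNc3cc(C(F)(F)F)cc(C(F)(F)F)c3)c(F)c2)C(=O)O1` — 3.1

In a physicochemical assay for lipophilicity, read by HPLC (on this read-out lower numbers stand for lower lipophilicity and higher numbers for higher lipophilicity), compound 1 gives 0.59, the lowest of the three readings. Compound 2 and compound 3 both sit higher, and each gap to compound 1 is beyond the usual scatter. Among the measured compounds shown here, no two measured compounds differ in a single place, so no measured step is available in this assay.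

Compound 4 `CC(=O)NC[C@H]1CN(c2ccc(OC[C@@H](O)CNC3CC3)c(F)c2)C(=O)O1` differs from compound 1 in one place: 2-(cyclopropylamino)-1-hydroxyethyl in place of 2-anilino-1-hydroxyethyl on a saturated chain carbon bound to an oxygen on an aromatic ring. In this assay that change is expected to lower the reading by a clear margin, and the step from compound 1 to compound 4 is estimated at a number 0.99 log units lower from compound 1 to compound 4 (beyond the scatter). Compound 4 is expected to read -0.4, with a range from -1.2 to 0.4.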

Compound 4, partition coefficient: 0.02
Compound 4: the middle estimate sits 0.42 log units below what was measured; the range from low to high includes it.
By their numbers in this assay, from the lowest: compound 4; then compound 1; then compound 2; then compound 3.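

In this assay, replacing the aromatic ring on the amine nitrogen with cyclopropyl lowers the reading on both available steps: a number 0.57 log units lower from compound 1 to compound 4 (beyond the scatter) and a number 2.10 log units lower from compound 2 to compound 4 (beyond the scatter). The second step is much the larger, and it is the cleaner read of the change, since compound 1 and compound 4 are also drawn with opposite configuration at the stereocentre. No measured evidence explains either step.

On these data alone, whether an open-chain isopropyl group on the amine nitrogen would read like cyclopropyl remains open. So does the effect of the stereocentre alone.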